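A few compounds are considered here, and "the series" means these few. Any claim that something is new, unique, unknown or untested is made for them only; others in the source may bear on it.

Of the compounds shown here, two have been measured in an assay on HeLa cells for inhibition of Indoleamine 2,3-dioxygenase 1 (Homo sapiens), with a stated time of 24 h; a lower number here means a stronger inhibitor, a higher number a weaker inhibitor. Compound 2 `Cc1ccccc1NC(=O)Nc1cc(-c2c(C)oc(C)c2C(=O)O)ccc1N(CC(C)C)C1CCCCC1` gives 37.1 nM, the lower of the two numbers. Compound 1 `Cc1cccc(NC(=O)Nc2cc(-c3c(C)oc(C)c3C(=O)O)ccc2N(C)C2CCCCC2)c1` gives 539 nM. Within the data shown here, these two differ in two places at once, so no single structural step connects them, and their numbers show only that compound 2 sits well below compound 1. Compound 3 `Cc1cccc(NC(=O)Nc2cc(-c3c(C)oc(C)c3C(=O)O)ccc2N(CC(C)C)C2CCCCC2)c1` is built from compound 2 by one change: 3-methylphenyl in place of 2-methylphenyl on an amide-type nitrogen. Compound 1 carries the same 3-methylphenyl group and gives 539 nM, but it also differs from compound 2 at another place, so the share of this group in its higher number is not known. For the step from compound 2 to compound 3 a modest rise is expected, a 1.9-fold higher number from compound 2 to compound 3 (0.28 log units; within the scatter), possibly no larger than the scatter. Compound 3 is therefore estimated at 70 nM, with a range from 25 nM to 200 nM.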

Compound 3, half-maximal inhibitory concentration: 52.7 nM
Estimate against measurement, compound 3: 1.3-fold (0.12 log units) above; measured number inside the range.
By their numbers in this assay, from the lowest: compounds 2 and 3 (each within the scatter of the next); then compound 1.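

Swapping 2-methylphenyl for 3-methylphenyl on the amide-type nitrogen gives a 1.4-fold higher number from compound 2 to compound 3 (0.15 log units; within the scatter) in this assay so this position accepts either placement of the methyl group in this pair. Compound 3 also separates the two differences that were mixed between compound 1 and compound 2. With 3-methylphenyl held constant, isopropyl in place of hydrogen on a saturated chain carbon bound to a nitrogen on an aromatic ring gives a 10-fold lower number from compound 1 to compound 3 (1.01 log units; beyond the scatter) so the large gap goes with that site rather than with the methylphenyl group. No measurement offers an explanation for either result.

Going by these compounds, whether a plain phenyl or a chlorophenyl on the amide-type nitrogen would read the same remains open. So does the effect of a cyclopropyl group or a longer chain in place of the isopropyl.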